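Compound 3 to compound 4: methoxy for chloro

The compounds below may be only part of what the source reports. "The series", "measured", "known", "first", "only" and "open" are said of these compounds alone.

In a functional assay on V79 cells (Cricetulus griseus) for cytotoxicity, read by colony formation (a higher number here means a weaker inhibitor, a lower number a stronger inhibitor), compound 3 `CNCC1(C)CCN(c2c(F)cc3c(=O)c(C(=O)O)cn(C4CC4)c3c2Cl)C1` gives 23 ug/mL as the higher of the two single readings among the compounds with the 3-methyl-3-((methylamino)methyl)pyrrolidin-1-yl group. The other is compound 2 `CNCC1(C)CCN(c2c(F)cc3c(=O)c(C(=O)O)cn(C4CC4)c3c2F)C1` at 8 ug/mL on the same scale. Compound 1 `CCNCC1CCN(c2c(F)cc3c(=O)c(C(=O)O)cn(C4CC4)c3c2OC)C1` carries methoxy without that pyrrolidinyl group and gives 22 ug/mL; 22 ug/mL (2 entries) in both of its entries, close to the reading of compound 3.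

Compound 4 `CNCC1(C)CCN(c2c(F)cc3c(=O)c(C(=O)O)cn(C4CC4)c3c2OC)C1` is still to be measured. The change is methoxy in place of chloro on an aromatic carbon and places methoxy in place of chloro on an aromatic carbon, ortho to the pyrrolidinyl group and meta to a fluoro group.

Among the measured compounds shown here, only one measured step touches this place: a 2.9-fold higher number from compound 2 to compound 3 (0.46 log units; beyond the scatter) is a modest change, and it concerns fluoro and chloro, not methoxy. For the measured compounds named here, no measured pair isolates methoxy with the amine of compound 4, so compound 1 is indirect evidence only. The reading for compound 1 of 22 ug/mL; 22 ug/mL (2 entries) nevertheless suggests that methoxy is compatible with numbers near that of compound 3. The expected change is a 1.2-fold lower number from compound 3 to compound 4 (0.06 log units; within the scatter) and therefore no step beyond the scatter in this assay for now.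

Compound 4 is estimated at 20 ug/mL (expected range 9 ug/mL to 45 ug/mL).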

Compound 4, half-maximal inhibitory concentration: 120 ug/mL
Compound 4: the middle estimate sits 6.0-fold (0.78 log units) below what was measured, and the stated range ends below it.
By their numbers in this assay, from the lowest: compound 2; then compound 3; then compound 4.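

In this assay, the position ortho to the 3-methyl-3-((methylamino)methyl)pyrrolidin-1-yl group now has three readings with that amine unchanged, and methoxy gives the highest number of the three, with a 5.2-fold higher number from compound 3 to compound 4 (0.72 log units; beyond the scatter) and a 15-fold higher number from compound 2 to compound 4 (1.18 log units; beyond the scatter). With the earlier 2.9-fold higher number from compound 2 to compound 3 (0.46 log units; beyond the scatter), every exchange among fluoro, chloro and methoxy at this position lies beyond the scatter, so among compound 2, compound 3 and compound 4 the aromatic substituent alone separates all three readings, and methoxy is the weakest inhibitor of these. Nothing measured accounts for this order, which stands as an observation on these three compounds only.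

The order rests on a single amine, so it remains open whether it would hold with the ethylaminomethyl group of compound 1, for which no chloro or fluoro partner is shown. Also open, going by these compounds, is how this position would read with a hydrogen, a methyl or an ethoxy group, which would show whether the rise seen with methoxy extends to other groups or is particular to it.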